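Swapping fluoro for bromo in compound 4

The compounds below may be only part of what the source reports. "The series", "measured", "known", "first", "only" and "open" are said of these compounds alone.

In a functional assay on A549 cells (Homo sapiens) for antiproliferative activity, read by MTT assay (on this read-out lower numbers stand for stronger inhibition and higher numbers for weaker inhibition), three compounds have values so far
Compound 1 `COc1cccc(Nc2nccc(-c3ccc(F)cc3)n2)c1` gives 35900 nM
Compound 2 `COc1cccc(Nc2nccc(-c3ccc(Cl)c(Cl)c3)n2)c1` gives 6000 nM
Compound 3 `O=[N+]([O-])c1ccc(Nc2nccc(-c3ccc(F)cc3)n2)cc1` gives 84000 nM

Compound 1 stands in the middle of these three numbers. Compound 3 has a higher number, which means weaker inhibition, and compound 2 has a lower number, which means stronger inhibition. Both gaps from compound 1 lie beyond the usual scatter of repeated measurements.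

The next compound to be tested is compound 4 `COc1cccc(Nc2nccc(-c3ccc(Br)cc3)n2)c1`, which keeps the core of compound 1 and has bromo in place of fluoro on an aromatic carbon. Among the compounds with values here, no two measured compounds differ in one place only, so no clean single change is available as a guide.

The nearest hint is thin. Compound 2, which carries chloro groups and no fluoro, reaches 6000 nM and so has a lower number than compound 1. On that single comparison, a moderate move toward stronger inhibition seems likely in this assay, though no change beyond the scatter remains possible. The expected step is (a 2.6-fold lower number from compound 1 to compound 4 (0.41 log units; beyond the scatter)) in size. For compound 4 the estimated value is 14000 nM, with 5000 nM to 36000 nM as the expected range.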

Compound 4, half-maximal inhibitory concentration: 82700 nM
Compound 4: the middle estimate sits 5.9-fold (0.77 log units) below what was measured; measured number above the stated range.
By their numbers in this assay, from the lowest: compound 2; then compound 1; then compounds 4 and 3 (each within the scatter of the next).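

In this assay, within the data shown here, the change from 4-fluorophenyl to 4-bromophenyl gives a 2.3-fold higher number from compound 1 to compound 4 (0.36 log units; beyond the scatter), the first clean single-change comparison in this set. The step is modest but lies beyond the usual scatter, so this position on the ring is sensitive to which group it carries, and here bromo goes with weaker inhibition than fluoro. No measurement shown here explains why the number rises with this swap.

Among these compounds, this is still only one pair on the core of compound 1, so it gives a direction for that single swap and not a trend across groups. Going by these compounds, it remains open how a single chloro, a methyl, a nitrile or an amine in the same place would compare with fluoro and bromo, and whether bromo in place of fluoro would give a similar step on the core of compound 3.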